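Testing a pyrazole carbonyl ester against a reversed amide

A few compounds are considered here, and "the series" means these few. Any claim that something is new, unique, unknown or untested is made for them only; others in the source may bear on it.

Within the data shown here, in a functional assay on LOX IMVI cells (Homo sapiens) for inhibition, read by sulforhodamine B assay, with a stated time of 48 h (on this read-out lower numbers stand for stronger inhibition of growth and higher numbers for weaker inhibition of growth), compound 2 (`CCCCCCCCCCCC[C@@H](O)[C@H]1CC[C@H]([C@H](O)CCCCCCCCCCC(=O)Nc2ccnn2C)O1`) gives 100000 nM and holds the highest of the two numbers so far. Compound 1 (`CCCCCCCCCCCC[C@@H](O)[C@H]1CC[C@H]([C@H](O)CCCCCCCCCCNC(=O)c2ccnn2C)O1`) gives 10 nM on the same read-out. Compound 3 (`CCCCCCCCCCCC[C@@H](O)[C@H]1CC[C@H]([C@H](O)CCCCCCCCCCOC(=O)c2ccnn2C)O1`) differs from compound 2 by ((1-methyl-1H-pyrazol-5-yl)carbonyl)oxy in place of (1-methyl-1H-pyrazol-5-yl)carbamoyl on a saturated chain carbon, ten or more bonds along the chain from an oxygen on a saturated carbon and a saturated ring carbon. Among the measured compounds shown here, the one measured step that bears on this is a 10000-fold higher number from compound 1 to compound 2 (4.00 log units; beyond the scatter) which is large and beyond the scatter. That step exchanged ((1-methyl-1H-pyrazol-5-yl)carbonyl)amino for (1-methyl-1H-pyrazol-5-yl)carbamoyl. The group entering compound 3 keeps the (1-methyl-1H-pyrazol-5-yl)carbonyl unit of compound 1, with oxy in place of amino. No measurement isolates that last exchange, and a full return to the number of compound 1 is not assumed. A large expected change is a 1000-fold lower number from compound 2 to compound 3 (3.00 log units; beyond the scatter) toward stronger inhibition of growth. For compound 3 the estimated value is 100 nM with 10 nM to 5000 nM as the expected range.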

Compound 3, concentration for 50% growth inhibition: 12900 nM
For compound 3 the middle estimate is 130-fold (2.11 log units) below the measured one; measured number above the stated range.
By their numbers in this assay, from the lowest: compound 1; then compound 3; then compound 2.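

Compound 3 keeps the (1-methyl-1H-pyrazol-5-yl)carbonyl unit of compound 1, yet in this assay putting oxy in place of amino gives a 1300-fold higher number from compound 1 to compound 3 (3.11 log units; beyond the scatter), so that unit alone does not carry the low number of compound 1 at this position on the chain. Replacing (1-methyl-1H-pyrazol-5-yl)carbamoyl with ((1-methyl-1H-pyrazol-5-yl)carbonyl)oxy gives only a 7.8-fold lower number from compound 2 to compound 3 (0.89 log units; beyond the scatter), a modest step that recovers a small part of the gap to compound 1, even though the entering group has no hydrogen-bond donor and the leaving group has one. Nothing measured here explains why these exchanges differ so much in size.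

The compounds shown leave open whether a urea, a carbamate or a plain amine on this saturated chain carbon would come close to compound 1 or stay near compound 3. They also leave open whether the ((1-methyl-1H-pyrazol-5-yl)carbonyl)amino group depends on its ring or its place, as a phenyl ring in place of the pyrazole or a longer chain would show.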